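A few compounds are considered here, and "the series" means these few. Any claim that something is new, unique, unknown or untested is made for them only; others in the source may bear on it.

In an ADME assay on L132 cells (Homo sapiens) for cytotoxicity, read by MTT assay, with a stated time of 48 h (on this read-out lower numbers stand for stronger inhibition and higher numbers for weaker inhibition), three compounds with a shared core have been tested. Compound 1 (`C/C(=C\CC/C(C)=C/CC[C@@H]1[C@@]2(C)CCC(=O)C(C)(C)[C@H]2CC[C@@]1(C)O)CC/C=C(\C)C(=O)OCc1cn(-c2ccc([N+](=O)[O-])cc2)nn1`) gives > 150000 nM here, a limit of the assay and not a number. Compound 2 (`C/C(=C\CC/C(C)=C/CC[C@@H]1[C@@]2(C)CCC(=O)C(C)(C)[C@H]2CC[C@@]1(C)O)CC/C=C(\C)C(=O)OCc1cn(-c2cccc(C)c2)nn1`) gives > 150000 nM here, again a limit. Compound 3 (`C/C(=C\CC/C(C)=C/CC[C@@H]1[C@@]2(C)CCC(=O)C(C)(C)[C@H]2CC[C@@]1(C)O)CC/C=C(\C)C(=O)OCc1cn(-c2cccc(Br)c2)nn1`) gives > 150000 nM here, also a limit, so it has no number of its own and stands with the other two (the limit of > 150000 nM in this assay, at which 3 of the 3 values shown sit). Compound 4 (`C/C(=C\CC/C(C)=C/CC[C@@H]1[C@@]2(C)CCC(=O)C(C)(C)[C@H]2CC[C@@]1(C)O)CC/C=C(\C)C(=O)OCc1cn(-c2ccccc2Cl)nn1`) differs from compound 3 in one group (2-chlorophenyl in place of 3-bromophenyl on an aromatic nitrogen): 2-chlorophenyl in place of 3-bromophenyl on an aromatic nitrogen. Among the compounds with values here, three steps bear on this: a step that the two limits leave unreadable from compound 1 to compound 2 and a step that the two limits leave unreadable from compound 1 to compound 3 and a step that the two limits leave unreadable from compound 2 to compound 3 are all without a readable size. No step beyond the scatter is therefore expected, so a step that the limit leaves unreadable from compound 3 to compound 4 is the expected step, and another limit is likely. Compound 4 is estimated at 200000 nM (expected range from 90000 nM to 450000 nM).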

Compound 4, half-maximal inhibitory concentration: > 150000 nM
Compound 4 ended at the assay's limit (the forecaster's own chance of this, stated with the estimate: 85%); the middle value is on the limit's open side.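

Compound 4 sits at the assay's limit, as do compound 1, compound 2 and compound 3, so no step among these compounds can be read: the limit of > 150000 nM in this assay, at which 4 of the 4 values shown sit. The compounds shown leave open whether changing the substituted phenyl group on the aromatic nitrogen affects this read-out at all.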